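Lengthening the amine chain of compound 3

The source may report more compounds than this note shows. Statements on the series, on what has been measured and on what is new or still open speak of the compounds shown alone.

Compound 3 `NCCCCc1c[nH]c2ccc(F)cc12` holds the lowest number of the three measured: in an assay on urine for inhibition of Myeloperoxidase (Homo sapiens) (on this read-out higher numbers stand for weaker inhibition and lower numbers for stronger inhibition), compound 3 gives 15 nM. Compound 1 `CNCCCc1c[nH]c2ccc(F)cc12` gives 200 nM in this assay, and compound 2 `Fc1ccc2[nH]cc(CCCN3CCCC3)c2c1` gives 320 nM. The step of a 1.6-fold higher number from compound 1 to compound 2 (0.20 log units; within the scatter) is small, whereas a 13-fold lower number from compound 1 to compound 3 (1.12 log units; beyond the scatter) and a 21-fold lower number from compound 2 to compound 3 (1.33 log units; beyond the scatter) are both large, so the unsubstituted amine terminus is what sets compound 3 apart on these numbers.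

Compound 4 `NCCCCCCc1c[nH]c2ccc(F)cc12` differs from compound 3 by 2-aminoethyl in place of amino on a saturated chain carbon, four bonds along the chain from an aromatic carbon. Within the data shown here, no measured step changes the length of the chain between the core and the amine; all three measured steps alter only the substitution on the nitrogen, and compound 4 keeps the primary amine of compound 3 unchanged. The measured steps therefore bear on compound 4 only indirectly: they say that the terminus compound 4 retains is the favourable one, but nothing about moving it two bonds further out. With the lengthening itself untested, the expected step in this assay is modest and of uncertain direction, leaning toward a somewhat higher number; the estimate is a 2.7-fold higher number from compound 3 to compound 4 (0.43 log units; beyond the scatter). Compound 4 is expected to give about 40 nM, with a range from 8 nM to 250 nM in this assay.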

Compound 4, half-maximal inhibitory concentration: 260 nM
Beside the measured number, compound 4's estimate is 6.5-fold (0.81 log units) below it; the whole stated range lies below it.
By their numbers in this assay, from the lowest: compound 3; then compounds 1, 4 and 2 (each within the scatter of the next).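

Among these compounds, compound 4 gives the first reading on how far the primary amine can sit from the core: keeping the amine but extending the chain yields a 17-fold higher number from compound 3 to compound 4 (1.24 log units; beyond the scatter) in this assay, so the unsubstituted terminus alone does not hold the low number of compound 3. At the saturated chain carbon three bonds along the chain from an aromatic carbon, 3-aminopropyl is not separated from the other larger groups, with a 1.2-fold lower number from compound 2 to compound 4 (0.09 log units; within the scatter) and a 1.3-fold higher number from compound 1 to compound 4 (0.11 log units; within the scatter), and only aminomethyl stands apart among the four groups compared there. The series therefore has a narrow requirement that involves both the substitution on the nitrogen and the length of the chain, and no available evidence accounts for the loss seen with the longer chain.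

The compounds shown leave open whether the rise sets in gradually or abruptly, which 2-aminoethyl at that same chain carbon would help to settle. They also leave open whether a shorter chain ending in the primary amine, or a carboxylic acid in place of the amine, would hold or lose the number of compound 3.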